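Dimethylpiperidine in Place of Piperidinylmethyl on a Shared Core

The source may hold more compounds than are shown below. What is called first, only, known or untested is meant among the compounds shown, and "the series" means these compounds.

The series rests on a shared core, seen in compound 1 `COc1ccc2[nH]c(C(=O)N3CC(=O)N(Cc4ccccc4)[C@@H](CN4CCCCC4)C3)cc2c1`, compound 2 `COc1ccc2[nH]c(C(=O)N3CC(=O)N(Cc4cc5ccccc5[nH]4)[C@@H](Cc4ccccc4)C3)cc2c1` and compound 3 `COc1cccc(CN2C(=O)CN(C(=O)c3cc4cc(OC)ccc4[nH]3)C[C@@H]2Cc2ccccn2)c1`. In a physicochemical assay for solubility, read by spectrophotometry, in phosphate buffer, with a stated time of 2 h, at pH 7.4 (on this read-out lower numbers stand for lower solubility and higher numbers for higher solubility), compound 1 gives only a limit of the assay, > 25000 nM. So compound 1 stands at the limit of > 25000 nM in this assay, at which 1 of the 3 values shown sits, and no number is known for it. Compound 2 gives 11000 nM in this assay, and compound 3 gives 57900 nM in this assay; these two numbers lie apart from one another, with compound 3 the higher of the pair.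

Compound 4 `COc1ccc2[nH]c(C(=O)N3CC(=O)N(Cc4ccccc4)[C@@H](N4[C@H](C)CCC[C@@H]4C)C3)cc2c1` has not been measured. It differs from compound 1 in one place: 2,6-dimethylpiperidin-1-yl in place of (piperidin-1-yl)methyl on a saturated ring carbon. The entering group carries two methyl groups and two defined stereocentres, and it is joined to the saturated ring carbon directly rather than through a methylene.

Because compound 1 sits at the limit of > 25000 nM in this assay, at which 1 of the 3 values shown sits, any step from it can only be read against a limit. The account expects the change to lower solubility by a modest step, an at least 1.3-fold lower number from compound 1 to compound 4 (0.14 log units; that floor lies within the scatter), which is estimated rather than measured, and which may in part fall within the usual scatter. On that basis compound 4 is estimated to give 18000 nM in this assay, expected between 6000 nM and 50000 nM.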

Compound 4, solubility: 100000 nM
Compound 4: middle estimate off by 5.6-fold (0.74 log units), on the low side; measured number above the stated range.
By their numbers in this assay, from the lowest: compound 2; then compounds 3 and 4 (each within the scatter of the next).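

Among these compounds, no step from compound 1 to compound 4 can be read, because compound 1 gives only a limit and not a number: the limit of > 25000 nM in this assay, at which 1 of the 4 values shown sits. The compounds shown leave open whether 2,6-dimethylpiperidin-1-yl in place of (piperidin-1-yl)methyl on a saturated ring carbon changes the number in this assay at all, and in which direction.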